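The source may report more compounds than this note shows. Statements on the series, on what has been measured and on what is new or still open speak of the compounds shown alone.

Measured so far in a functional assay (plasma) for inhibition, with Oryctolagus cuniculus as the target; a lower number here means a stronger inhibitor, a higher number a weaker inhibitor:
- compound 1, `CN(C)c1ccc(S(=O)(=O)N[C@H]2C3CC[C@H](C3)[C@@H]2C/C=C\CCCC(=O)O)cc1`: 7100 nM
- compound 2, `O=C(O)CCC/C=C\C[C@H]1[C@@H]2CCC(C2)[C@@H]1NS(=O)(=O)c1ccccc1`: 1000 nM; 7400 nM; 600 nM (3 entries)

Within the data shown here, compound 1 gives the only single number in this assay; compound 2 has several entries that spread widely, (the several entries of compound 2 in this assay, 1000 nM; 7400 nM; 600 nM (3 entries)), and the value of compound 1 falls within that spread. No pair of measured compounds differing in one place is available, so the size of a change in this assay cannot be read from the numbers shown. The two values of compound 1 and compound 2 together show only that the spread of this series runs from the lower entries of compound 2 up to the figure of compound 1.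

Compound 3, `O=C(O)CCC/C=C\C[C@H]1[C@@H]2CCC(C2)[C@@H]1NS(=O)(=O)CCc1ccccc1`, is not yet measured. It differs from compound 1 by phenethyl in place of 4-(dimethylamino)phenyl on a sulfonyl sulfur. The change is expected to move the number down rather than up, by a step of modest size, as the aromatic sulfonamide of compound 2 already reaches the lower entries in the several entries of compound 2 in this assay, 1000 nM; 7400 nM; 600 nM (3 entries). The expected step from compound 1 to compound 3 is a 3.6-fold lower number from compound 1 to compound 3 (0.55 log units; beyond the scatter). For compound 3 the expected value is 2000 nM, with a range from 400 nM to 10000 nM.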

Compound 3, half-maximal inhibitory concentration: 8200 nM
Estimate against measurement, compound 3: 4.1-fold (0.61 log units) below, within the range that was stated.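

Phenethyl in place of 4-(dimethylamino)phenyl on a sulfonyl sulfur gives, in this assay, a 1.2-fold higher number from compound 1 to compound 3 (0.06 log units; within the scatter). Among these compounds, this is the first one-place comparison, and it shows that at this position the read-out does not separate the two groups, although the aromatic ring of the entering group carries no dimethylamino group and the entering group has no hydrogen-bond acceptor where the leaving group has one. Neither compound 1 nor compound 3 can be placed against the aromatic sulfonamide of compound 2, and no step to that compound can be read, because its entries spread too widely to give one reference value: the several entries of compound 2 in this assay, 1000 nM; 7400 nM; 600 nM (3 entries)

Among the compounds shown here, the single exchange sets no trend for this position, and it does not separate any contribution of the dimethylamino group from that of the two-carbon link in phenethyl. Still open, from the compounds shown here alone, is how the number responds to a simple methyl on the sulfonyl sulfur, a longer chain ending in phenyl, or a phenethyl group bearing an amine on its ring.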